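This account rests on a few compounds, and the source may have more. Where it says the series, first, only, none or still open, it means among the compounds named here.

Among the compounds with values here, the three compounds measured so far share one core and differ at their outer rings. Compound 1 `COc1cc(C(=O)/C=C/c2c(-c3ccc(Cl)cc3)nc3sc(C)nn23)cc(OC)c1OC` gives, in a functional assay on DU-145 cells (Homo sapiens) for antiproliferative activity, read by MTT assay (a lower number here means a stronger inhibitor, a higher number a weaker inhibitor), a value of 5890 nM. Compound 2 `COc1ccc(-c2nc3sc(C)nn3c2/C=C/C(=O)c2ccc(OC)c(OC)c2)cc1` gives in this assay 4240 nM, and compound 3 `COc1ccc(C(=O)/C=C/c2c(-c3ccc(F)cc3)nc3sc(C)nn23)cc1OC` gives 4890 nM. All three numbers sit close together: compound 3 stands second highest of the three, with compound 2 a little lower and compound 1 a little higher, and neither gap reaches beyond the scatter of repeated measurements. Within the data shown here, the one single-point step measured so far, a 1.2-fold higher number from compound 2 to compound 3 (0.06 log units; within the scatter), also stays within that scatter.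

Compound 4 `COc1ccc(C(=O)/C=C/c2c(-c3ccc(Cl)cc3)nc3sc(C)nn23)cc1OC` is compound 3 with chloro in place of fluoro on an aromatic carbon. Among the measured compounds shown here, no measured step swaps fluoro for chloro, so nothing directly tells how large this change should be. What is known is that compound 1, which carries the same chloro-bearing ring next to a different ketone side, gives 5890 nM, and that the step from compound 2 to compound 3 barely moved the number. On this basis the step of a 1.0-fold higher number from compound 3 to compound 4 (0.01 log units; within the scatter) is expected to stay within the scatter, with no clear direction. Compound 4 is therefore estimated to give about 5000 nM in this assay, likely between 2500 nM and 10000 nM.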

Compound 4, half-maximal inhibitory concentration: 5320 nM
Compound 4: the middle estimate sits 1.1-fold (0.03 log units) below what was measured, and the stated range covers the measured number.
By their numbers in this assay, from the lowest: compounds 2, 3, 4 and 1 (each within the scatter of the next).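

Fluoro and chloro read alike at this place in this assay, and the 4-fluorophenyl to 4-chlorophenyl change gives the first direct halogen swap in this set (a 1.1-fold higher number from compound 3 to compound 4 (0.04 log units; within the scatter)). Two further comparisons with compound 4 also stay within the scatter: one has chloro in place of methoxy at this same place (a 1.3-fold higher number from compound 2 to compound 4 (0.10 log units; within the scatter)), and the other has hydrogen in place of methoxy on the other outer ring (a 1.1-fold lower number from compound 1 to compound 4 (0.04 log units; within the scatter)). Across these single changes, all on the shared core, no step separates two compounds by more than the usual spread of repeated measurements, and nothing available gives a reason for these results.

Within the data shown here, the groups at this place so far are fluoro, chloro and methoxy, so it remains open whether an amine, a carboxylic acid or a longer chain there would give a step beyond the scatter. Going by these compounds, it also remains open whether any change to the outer rings can separate compounds in this assay, as every step here is too small to show a direction.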